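Biaryl tail swap in a cyclopropane-carboxamide series

The compounds below may be only part of what the source reports. "The series", "measured", "known", "first", "only" and "open" are said of these compounds alone.

Two compounds of the series have a result in a functional assay for agonist activity at G protein-coupled receptor 88 (Homo sapiens), read by HTRF and cAMP accumulation; a lower number here means that less compound is needed, a higher number that more compound is needed for the effect. Compound 1, `CC[C@H](C)[C@H](N)CN(C(=O)[C@@H]1C[C@H]1c1nc(C)c(C)s1)c1ccc(-c2ccccc2)cc1`, gives 3600 nM. Compound 2, `CC(C)C[C@H](N)CN(C(=O)[C@@H]1C[C@H]1c1ccccc1)c1ccc(-c2ccsc2)cc1`, gives 1200 nM and stands lowest of the two numbers, with compound 1 as its nearest neighbour at a gap beyond the scatter. Within the data shown here, the two differ in more than one place, so no single step between them can be read off.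

Compound 3, `CC(C)C[C@H](N)CN(C(=O)[C@@H]1C[C@H]1c1ccccc1)c1ccc(-c2ccc(F)cc2)cc1`, is not yet measured; it differs from compound 2 in one place: 4-fluorophenyl in place of thiophen-3-yl on an aromatic carbon. Among the measured compounds shown here, no measured pair shows the effect of such a swap, so the expected step rests on compound 2 alone and is taken as none beyond the scatter, with the direction open. Compound 3 is expected to give about 1100 nM, in the range 400 nM to 3200 nM. The estimated step is a 1.1-fold lower number from compound 2 to compound 3 (0.04 log units; within the scatter), expected to fall within the scatter.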

Compound 3, half-maximal effective concentration: 900 nM
Estimate against measurement, compound 3: 1.2-fold (0.09 log units) above; the range from low to high includes it.
By their numbers in this assay, from the lowest: compounds 3 and 2 (each within the scatter of the next); then compound 1.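

In this assay, the swap of thiophen-3-yl for 4-fluorophenyl gives the series its first comparison that differs in one place, on an aromatic carbon para to a large group: a 1.3-fold lower number from compound 2 to compound 3 (0.12 log units; within the scatter), so the two groups cannot be told apart in this assay. With the rest of compound 2 held fixed, a five-membered aromatic ring with one hetero atom and a six-membered aromatic ring of carbon only are therefore both compatible with activity at this position. No measurement at hand offers an explanation for this result.

As far as these compounds go, whether an unsubstituted phenyl, a pyridine or a nitrile-bearing phenyl at this position would also stay within the scatter remains open. From the compounds shown here alone, compound 1 differs from compound 2 and compound 3 in more than one place, so its steps to them cannot be read, and whether the swap carries over to its side chain and amide group is also open.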